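From a Methylimidazole Sulfonyl Group to a Bromophenyl

The source may hold more compounds than are shown below. What is called first, only, known or untested is meant among the compounds shown, and "the series" means these compounds.

Within the data shown here, all four compounds share a core in which a sulfonyl sulfur joins a small aromatic ring to a ring nitrogen, and only that aromatic ring changes. Compound 1 `Cc1noc(C)c1S(=O)(=O)N1CCC(N2CCC(C)CC2)CC1` carries a 3,5-dimethyl-1,2-oxazol-4-yl there. In a functional assay on DLD-1 cells (Homo sapiens) for antiproliferative activity, read by CellTiter-Glo, with a stated time of 72 h (a lower number here means a stronger inhibitor, a higher number a weaker inhibitor), compound 1 gives > 5000 nM, which is a limit of the assay and not a number. Compound 2 `CC1CCN(C2CCN(S(=O)(=O)c3cnc(Cl)s3)CC2)CC1` has a 2-chloro-1,3-thiazol-5-yl in its place, and in this assay compound 2 gives 1800 nM. Compound 3 `CC1CCN(C2CCN(S(=O)(=O)c3cn(C)cn3)CC2)CC1` carries a 1-methyl-1H-imidazol-4-yl. In this assay compound 3 gives > 5000 nM, again a limit of the assay rather than a number. Compound 3 therefore sits at the limit of > 5000 nM in this assay, at which 2 of the 3 values shown sit, the weak end of what has been measured. The step of an at least 2.7-fold lower number from compound 1 to compound 2 (0.44 log units; beyond the scatter) and the step of an at least 2.7-fold higher number from compound 2 to compound 3 (0.44 log units; beyond the scatter) show that swapping the ring on the sulfonyl sulfur can move the number beyond the scatter, while a step that the two limits leave unreadable from compound 1 to compound 3.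

Compound 4 `CC1CCN(C2CCN(S(=O)(=O)c3cccc(Br)c3)CC2)CC1` makes the next change: 3-bromophenyl in place of 1-methyl-1H-imidazol-4-yl on a sulfonyl sulfur. Among the measured compounds shown here, no measured step involves a carbon-only ring, so the earlier steps bear on this one only by showing that the ring at this position matters. Compound 4 is expected to give about 1500 nM, within 300 nM to 6000 nM. That estimate means an expected step of an at least 3.3-fold lower number from compound 3 to compound 4 (0.52 log units; beyond the scatter), though a limit is again possible.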

Compound 4, half-maximal inhibitory concentration: 3.2 nM
Beside the measured number, compound 4's estimate is 470-fold (2.67 log units) above it; the whole stated range lies above it.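

Replacing the ring on the sulfonyl sulfur with 3-bromophenyl gives a 560-fold lower number from compound 2 to compound 4 (2.75 log units; beyond the scatter) in this assay, so this position can move the number far more than the changes among the three five-membered rings had shown. The steps from the two compounds held at a limit of the assay are an at least 1500-fold lower number from compound 3 to compound 4 (3.19 log units; beyond the scatter) and an at least 1500-fold lower number from compound 1 to compound 4 (3.19 log units; beyond the scatter), and neither gives an exact size: the limit of > 5000 nM in this assay, at which 2 of the 4 values shown sit. Among the compounds shown, only compound 4 has a six-membered aromatic ring of carbon only, and it alone reaches this range in this assay.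

The compounds shown cannot separate the contribution of the phenyl ring from that of the bromine; a plain phenyl, or a chlorine or nitrile in place of the bromine, would address this. Going by these compounds, how an amine or a carboxylic acid on that ring would read also remains open.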